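The compounds below may be only part of what the source reports. "The series", "measured", "known", "first", "only" and "open" are said of these compounds alone.

Measured so far:
compound 1 `Cc1ccc(NC(=O)C(=O)NC(c2nc(C)c(CCO)s2)C2CCCCN2)c(F)c1` — in an ADME assay on TZM-b1 cells (Homo sapiens) for cytotoxicity, read by XTT assay, with a stated time of 3 days (a lower number here means that less compound is tolerated, a higher number that more compound is tolerated), compound 1 gives > 78800 nM, a limit of the assay rather than a number.
compound 2 `Cc1nc(C(NC(=O)C(=O)Nc2ccc(Cl)c(F)c2)C2CCCCN2)sc1CCO` — in this assay compound 2 gives 61000 nM.

Among the measured compounds shown here, compound 2 therefore holds the only number; the one other value is a limit. For the measured compounds named here, the single measured step, an at least 1.2-fold lower number from compound 1 to compound 2 (0.11 log units; that floor lies within the scatter), is the swap of one aryl group for another on the amide-type nitrogen, and its floor sits within the scatter, so the two compounds cannot be told apart; the limit is stated as the limit of > 78800 nM in this assay, at which 1 of the 2 values shown sits.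

Compound 3 `Cc1nc(C(NC(=O)C(=O)Nc2ccc(F)cc2)C2CCCCN2)sc1CCO` carries the change (4-fluorophenyl in place of 4-chloro-3-fluorophenyl on an amide-type nitrogen). Going by the values given here, only the step from compound 1 to compound 2 bears on it, since it alters the same aryl group on the same amide-type nitrogen, and that step stayed within the scatter. Nothing in the data points to a shift beyond the scatter in either direction for compound 3, and a limit rather than a number is a real possibility. The estimated step of a 1.2-fold higher number from compound 2 to compound 3 (0.09 log units; within the scatter) is expected to fall within the scatter. Compound 3 is expected to give 75000 nM, with a range from 40000 nM to 150000 nM.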

Compound 3, half-maximal cytotoxic concentration: > 88000 nM
Compound 3 was reported as a limit (the forecaster's own chance of this, stated with the estimate: 50%); middle value at least 1.1-fold (0.06 log units) from the limit.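

Going from 4-chloro-3-fluorophenyl to 4-fluorophenyl on the amide-type nitrogen gives, in this assay, an at least 1.4-fold higher number from compound 2 to compound 3 (0.15 log units; that floor lies within the scatter), so a second aryl change at this position also stays, at its floor, inside the scatter. Compound 3 gives a limit and not a number: the limit of > 88000 nM in this assay, at which 1 of the 3 values shown sits.

The step between compound 1 and compound 3 cannot be read, as both values are limits, so across 2-fluoro-4-methylphenyl, 4-chloro-3-fluorophenyl and 4-fluorophenyl no readable step at this position lies beyond the scatter, and compound 2 alone holds a number.

Still open, from the compounds shown here alone, is how far the true values of compound 1 and compound 3 lie from compound 2, since the floors of their steps say nothing about the full size of the gap. Also open, going by these compounds, is whether a phenyl group carrying an amine or a carboxylic acid, or an unsubstituted phenyl group, on the same amide-type nitrogen would move the number in this assay beyond the scatter in either direction.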